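Swapping a nitrile for chlorine on an amide-linked ring

This account rests on a few compounds, and the source may have more. Where it says the series, first, only, none or still open, it means among the compounds named here.

Of the compounds shown here, three sharing one core have been tested so far. Compound 1 `N#Cc1cc(Cl)ccc1NC(=O)c1ccc2cccnc2c1O` carries a cyano group and a chloro group on the ring attached to the amide nitrogen; in a functional assay on KG-1 cells (Homo sapiens) for cytotoxicity, read by luminescence and CellTiter-Glo, with a stated time of 3 days (on this read-out higher numbers stand for weaker inhibition and lower numbers for stronger inhibition), compound 1 gives 3540 nM. Compound 2 `O=C(Nc1ccc(Cl)cc1)c1ccc2cccnc2c1O` keeps only the chloro group, and in this assay compound 2 gives 3300 nM. Among the compounds with values here, the one change between them, hydrogen in place of cyano on an aromatic carbon, produced a 1.1-fold lower number from compound 1 to compound 2 (0.03 log units; within the scatter). Compound 3 `N#Cc1ccc(NC(=O)c2ccc3cccnc3c2O)c(Cl)c1` places the cyano and chloro groups differently on that same ring; in this assay compound 3 gives 3670 nM, a number that sits within the scatter of both compound 1 and compound 2, so nothing separates the three.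

Compound 4 `O=C(Nc1ccc(Cl)cc1Cl)c1ccc2cccnc2c1O` differs from compound 3 in one place: chloro in place of cyano on an aromatic carbon. Within the data shown here, the only measured step that bears on this is the removal of the cyano group from compound 1 to compound 2, which stayed within the scatter. Since dropping the cyano group changed little there, replacing it with chloro is expected to change little here, with a 1.0-fold lower number from compound 3 to compound 4 (0.02 log units; within the scatter) as the expected step. Compound 4 is estimated at 3500 nM, within a range from 1500 nM to 8000 nM.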

Compound 4, half-maximal inhibitory concentration: 3560 nM
Beside the measured number, compound 4's estimate is 1.0-fold (0.01 log units) below it; the measured number falls inside the stated range.
By their numbers in this assay, from the lowest: compounds 2, 1, 4 and 3 (each within the scatter of the next).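

In this assay, chloro in place of cyano, on the aromatic carbon meta to a chloro group and para to a large group, gives a 1.0-fold lower number from compound 3 to compound 4 (0.01 log units; within the scatter), so this position now holds two different groups with no readable difference between them. Compound 4 also shows that adding a chloro group, rather than only removing a cyano group, leaves the read-out within the scatter: chloro in place of hydrogen gives a 1.1-fold higher number from compound 2 to compound 4 (0.03 log units; within the scatter), and chloro in place of cyano gives a 1.0-fold higher number from compound 1 to compound 4 (0.00 log units; within the scatter), so hydrogen, cyano and chloro on this ring have so far given no step beyond the scatter in these four compounds. Nothing here explains why these exchanges leave the number in the same range.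

On these data alone, with every step inside the scatter, it remains open whether any group on this ring can shift the number, for instance an amine, a carboxylic acid or a longer chain such as a butyl group in place of the chloro or cyano groups. As far as these compounds go, all four compounds also share the same core, so what its parts contribute to the cytotoxicity remains unknown.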